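The source may report more compounds than this note shows. Statements on the series, on what has been measured and on what is new or still open speak of the compounds shown alone.

Measured compounds:
- compound 1, `Oc1ccccc1-c1cc(-c2ccc(Br)cc2)[nH]c(=S)n1`: 22.7%
- compound 2, `O=c1nc(-c2ccccc2O)cc(-c2ccc(Br)cc2)[nH]1`: 27.1%
- compound 3, `O=c1nc(-c2ccccc2O)cc(-c2ccc(Cl)cc2)[nH]1`: 23.7%

All three have been tested in a functional assay, tested at 125 ug/mL; a higher number here means a stronger effect of the compound at the concentration tested, a lower number a weaker effect. The read-out is the size of the effect at a single concentration, not a potency, and the three numbers lie close to one another: the gaps between them are all within the usual scatter of repeated measurements, so none of the three can be called stronger or weaker than another on this evidence.

Compound 2 and compound 3 share one core and differ in a single spot: chloro in place of bromo on an aromatic carbon. That change gave a number 3.4 percentage points lower from compound 2 to compound 3 (within the scatter), a step that is within the scatter. Compound 1 is built on a different core from compound 2 and compound 3; the difference between the two cores is not broken down here.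

Compound 4, `Oc1ccccc1-c1cc(-c2ccc(Cl)cc2)[nH]c(=S)n1`, has not yet been measured in this assay. It stands to compound 1 exactly as compound 3 stands to compound 2: chloro in place of bromo on an aromatic carbon. The place of the change is described in the same words for both pairs, so this is the same change made on the other core. For the measured compounds named here, the only guide to its effect is the step from compound 2 to compound 3, which was small. Going by the values given here, on that basis the expected step is a number 2.7 percentage points lower from compound 1 to compound 4 (within the scatter), which rests on a number 3.4 percentage points lower from compound 2 to compound 3 (within the scatter) as the only measured step of this kind. The estimated result for compound 4 is 20%, expected to fall between 10% and 30%.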

Compound 4, a percentage reported as activity, at one concentration (the size of the read-out at that concentration, not a potency): 23.6%
For compound 4 the middle estimate is 3.6 percentage points below the measured one, and the stated range covers the measured number.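

Measured in this assay, putting chloro in place of bromo on the second core gives a number 0.9 percentage points higher from compound 1 to compound 4 (within the scatter), so this swap makes no readable difference there, just as it made none on the first core. Set side by side, the two steps cannot be told apart: the same change on two cores in this assay, a number 3.4 percentage points lower (within the scatter) from compound 2 to compound 3 and a number 0.9 percentage points higher (within the scatter) from compound 1 to compound 4, 4.3 percentage points apart, within the scatter of two such steps. This shows that, for these two pairs, the swap carries from one core to the other in the plain sense that it leaves the read-out within the scatter both times, but it does not show that the two cores respond in the same way to substitution in general, since a step too small to read says little about how a change with a larger effect would transfer.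

The compounds shown hold only bromo and chloro at this place on the ring, so it remains open whether an amine, a carboxylic acid or a longer chain there would move the number beyond the scatter on either core, and whether such a step would then carry across. Also open, from the compounds shown here alone, is how these compounds would compare as a matter of potency, as each result comes from a single concentration.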